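Methyl Addition and Microsomal Stability in Two Related Pairs

This account rests on a few compounds, and the source may have more. Where it says the series, first, only, none or still open, it means among the compounds named here.

Compound 1 `C[C@H](Nc1ncnc2[nH]cnc12)c1cc2ccccn2c(=O)c1-c1ccccc1` gives 93% in an ADME assay on microsomes from liver (Rattus norvegicus), read by LC-MS, using NADPH, with a stated time of 30 min, tested at 1 uM; a higher number here means that more of the compound is left, a lower number that less of the compound is left. Compound 2 `Cc1cccc2cc([C@H](C)Nc3ncnc4[nH]cnc34)c(-c3ccccc3)c(=O)n12` carries methyl in place of hydrogen on an aromatic carbon and in this assay gives 73%, a change of a number 20 percentage points lower from compound 1 to compound 2 (beyond the scatter). Compound 3 `C[C@H](Nc1nc(N)nc(N)c1C#N)c1cc2ccc(F)cn2c(=O)c1-c1ccccc1` has a different core; the difference between the two cores is not broken down here. In this assay compound 3 gives 88%, a value above that of compound 2, while the gap to compound 1 lies within the scatter.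

Compound 4 `Cc1cccc(-c2c([C@H](C)Nc3nc(N)nc(N)c3C#N)cc3ccc(F)cn3c2=O)c1` carries methyl in place of hydrogen on an aromatic carbon. This is the same kind of change as that from compound 1 to compound 2, but at a different place: there on a six-membered aromatic ring with one nitrogen, part of a fused system, next to the ring nitrogen; here on a six-membered ring of carbon only, meta to a large group. Because the earlier change gave a number 20 percentage points lower from compound 1 to compound 2 (beyond the scatter), a downward step is expected for compound 4 as well, though the different surroundings make its size uncertain, and the estimate is a number 14 percentage points lower from compound 3 to compound 4 (beyond the scatter). Compound 4 is thus expected to give 74%, likely between 55% and 90%.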

Compound 4, percent of the compound remaining: 77%
Beside the measured number, compound 4's estimate is 3 percentage points below it; the measured number falls inside the stated range.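

In this assay, methyl in place of hydrogen on an aromatic carbon again gives a lower value, a number 11 percentage points lower from compound 3 to compound 4 (beyond the scatter). Set beside the earlier step, the change keeps its direction on the second core, and the two sizes cannot be told apart: the same change on two cores in this assay, a number 20 percentage points lower (beyond the scatter) from compound 1 to compound 2 and a number 11 percentage points lower (beyond the scatter) from compound 3 to compound 4, 9 percentage points apart, within the scatter of two such steps. For the compounds shown here, this does not show that the step would hold at any other place or on any further core: there are only two pairs, the methyl sits at a different place in each, and the part played by the core cannot be separated from that of the place.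

The compounds shown leave open whether an ethyl or a methoxy group on the same aromatic carbon would give a similar step. They also leave open what 3-methylphenyl would give on the core of compound 1.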